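Moving chloro and fluoro around the aniline ring

The compounds below may be only part of what the source reports. "The series", "measured", "known", "first", "only" and "open" are said of these compounds alone.

Measured compounds:
Compound 1, `Cc1n[nH]c2ccc(-c3nc4cnc(N5CCN(C)CC5)cn4c3Nc3ccccc3F)cc12`, 0% in a functional assay on MV4-11 cells (Homo sapiens) for inhibition, with a stated time of 120 h, tested at 10 uM; a lower number here means less inhibition, a higher number more inhibition at the concentration tested (going by the name of the read-out).
Compound 2, `Cc1n[nH]c2ccc(-c3nc4cnc(N5CCN(C)CC5)cn4c3Nc3ccccc3Cl)cc12`, 58.1%.
Compound 3, `Cc1n[nH]c2ccc(-c3nc4cnc(N5CCN(C)CC5)cn4c3Nc3ccc(Cl)cc3F)cc12`, 0%.

Compound 3 stands level with compound 1 at the bottom of the three, far beneath compound 2; the step of a number 58.1 percentage points lower from compound 2 to compound 3 (beyond the scatter) marks that gap, while no change at the digits printed from compound 1 to compound 3 (within the scatter) shows no shift. Compound 4, `Cc1n[nH]c2ccc(-c3nc4cnc(N5CCN(C)CC5)cn4c3Nc3ccc(F)c(Cl)c3)cc12`, keeps the same atoms but rearranges them: 3-chloro-4-fluorophenyl in place of 4-chloro-2-fluorophenyl on a nitrogen on an aromatic ring. Going by the values given here, two steps bear on this. The change a number 58.1 percentage points higher from compound 1 to compound 2 (beyond the scatter) shows that swapping one halogen for another can matter greatly, whereas no change at the digits printed from compound 1 to compound 3 (within the scatter) shows that adding a chloro elsewhere did nothing. Among the compounds with values here, since no measured pair moves both halogens at once, the outcome is uncertain; a modest rise of a number 20 percentage points higher from compound 3 to compound 4 (beyond the scatter) is expected. Compound 4 is estimated at 20%, within 0% to 55%.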

Compound 4, a percentage reported as inhibition, at one concentration (the size of the read-out at that concentration, not a potency): 84.1%
The estimate for compound 4 lay 64.1 percentage points below the measured number, outside the stated range (above it).
By their numbers in this assay, from the lowest: compounds 1 and 3 (each within the scatter of the next); then compound 2; then compound 4.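

Rearranging the same two halogens on this ring gives a number 84.1 percentage points higher from compound 3 to compound 4 (beyond the scatter), so in this assay the arrangement of the atoms matters, not just their presence. The 3-chloro-4-fluorophenyl group also outdoes the other two rings, with a number 26 percentage points higher from compound 2 to compound 4 (beyond the scatter) and a number 84.1 percentage points higher from compound 1 to compound 4 (beyond the scatter). Nothing available explains these differences. Still open, from the compounds shown here alone, is how much the chloro and the fluoro of compound 4 each contribute, and whether a methoxy or a nitrile on this ring would keep the inhibition.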